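Amino for hydrogen on the shared core: cytotoxicity notes

The source may report more compounds than this note shows. Statements on the series, on what has been measured and on what is new or still open speak of the compounds shown alone.

Measured so far:
compound 1 `ClCc1ccc(Cn2cnc3c(Cl)ncnc32)cc1`: in a functional assay on NCI-H522 cells (Homo sapiens) for cytotoxicity, read by sulforhodamine B assay, with a stated time of 48 h (on this read-out higher numbers stand for lower toxicity in this test and lower numbers for higher toxicity in this test), compound 1 gives > 100000 nM, a limit of the assay.
compound 2 `Nc1nc(Cl)c2ncn(Cc3ccc(CCl)cc3)c2n1`: in this assay compound 2 gives 63100 nM.
compound 3 `ClCc1ccccc1Cn1cnc2c(Cl)ncnc21`: in this assay compound 3 gives > 100000 nM, a limit of the assay.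

For the measured compounds named here, the one counted change is amino in place of hydrogen on an aromatic carbon, which made an at least 1.5-fold lower number from compound 1 to compound 2 (0.19 log units; that floor lies within the scatter). The difference between the core of compound 1 and the core of compound 3 is not broken down here. Compound 4 `Nc1nc(Cl)c2ncn(Cc3ccccc3CCl)c2n1` carries the same change on the core of compound 3, (amino in place of hydrogen on an aromatic carbon), the place being the same word for word. Compound 3 is known only as a limit, and the limit of > 100000 nM in this assay, at which 2 of the 3 values shown sit, leaves the starting point open. For compound 4 in this assay a step of an at least 1.2-fold lower number from compound 3 to compound 4 (0.09 log units; that floor lies within the scatter) is expected, resting on an at least 1.5-fold lower number from compound 1 to compound 2 (0.19 log units; that floor lies within the scatter). Compound 4 is estimated at 80000 nM, between 35000 nM and 200000 nM.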

Compound 4, concentration lethal to 50% of the cells: > 100000 nM
Compound 4 ended at the assay's limit; the forecaster's own chance of this, stated with the estimate: 45%; at least 1.2-fold (0.09 log units) between middle value and limit.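

Compound 3 and compound 4 both end at a limit of the assay, so no step can be read between them: the limit of > 100000 nM in this assay, at which 3 of the 4 values shown sit. On these data alone, whether amino in place of hydrogen changes the number on the core of compound 3 stays open.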